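A few compounds are considered here, and "the series" means these few. Any claim that something is new, unique, unknown or untested is made for them only; others in the source may bear on it.

Measured in a functional assay on HCT-116 cells (Homo sapiens) for inhibition; on this read-out lower numbers stand for stronger inhibition and higher numbers for weaker inhibition:
- compound 1 `CCNCc1cc(-c2c(C(=O)NCC)noc2-c2cc(C(C)C)c(O)cc2O)on1`: 45 nM
- compound 2 `CCNC(=O)c1noc(-c2cc(C(C)C)c(O)cc2O)c1-c1cc(C(=O)OCC)no1`: "not determined" (no result reported)
- compound 3 `CCNC(=O)c1noc(-c2cc(C(C)C)c(O)cc2O)c1-c1cc(C(=O)O)no1`: "not determined" (no result reported)

Only compound 1 has a number here. Compound 3 stands without one, and so does compound 2, so there is no measured value from which to start the step that follows.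

That step leads to compound 4 `CCNC(=O)c1noc(-c2cc(C(C)C)c(O)cc2O)c1-c1cc(C(N)=O)no1`, which has not yet been measured. The structural change is amino in place of hydroxy on a carbonyl carbon, which turns carboxy into carbamoyl and gives a 3-carbamoyl-1,2-oxazol-5-yl group. Among the compounds with values here, with no measured step of this kind to draw on, its size in this assay can only be a cautious guess. A moderate step towards stronger inhibition is expected, but with compound 3 at "not determined" (no result reported) it cannot be checked against a starting number. Within the data shown here, the single available anchor is compound 1 at 45 nM, so the range has to stay wide. For compound 4 the estimated value is 100 nM, with an expected range from 20 nM to 500 nM.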

Compound 4, half-maximal inhibitory concentration: 79 nM
Compound 4: the middle estimate sits 1.3-fold (0.10 log units) above what was measured, within the range that was stated.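

In this assay, a second measured group can now be compared at this aromatic carbon: carbamoyl in place of (ethylamino)methyl gives a 1.8-fold higher number from compound 1 to compound 4 (0.24 log units; within the scatter). Compound 1 and compound 4 therefore cannot be told apart on this read-out, so this position accepts either group without a change that stands clear of the scatter. No measured information is available to explain this result.

The steps from compound 2 and compound 3 to compound 4 cannot be read, as neither starting compound has a number, so the change from carboxy to carbamoyl remains unsized. The compounds shown also leave open how a primary aminomethyl group, a hydroxymethyl group or a longer chain on the amine, such as propylamino in place of ethylamino, would read at this position.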